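Swapping the diethylamino for an imidazolyl ring

The source may report more compounds than this note shows. Statements on the series, on what has been measured and on what is new or still open speak of the compounds shown alone.

Measured so far in a functional assay on HT-29 cells (Homo sapiens) for antiproliferative activity, read by MTT assay, with a stated time of 24 h; on this read-out higher numbers stand for weaker inhibition and lower numbers for stronger inhibition:
- compound 1 `COc1ccc(C(=O)/C=C/c2ccc(N(C)C)cc2)c2c1C=CC(C)(C)O2` gives 1870 nM
- compound 2 `CCN(CC)c1ccc(/C=C/C(=O)c2ccc(OC)c3c2OC(C)(C)C=C3)cc1` gives 550 nM

Compound 2 has the lowest of the two numbers. Among the measured compounds shown here, the only step in the set, a 3.4-fold lower number from compound 1 to compound 2 (0.53 log units; beyond the scatter), is modest yet beyond the scatter, and it exchanges one dialkylamino group for a larger one on the same aromatic carbon.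

Compound 3 `COc1ccc(C(=O)/C=C/c2ccc(-n3ccnc3)cc2)c2c1C=CC(C)(C)O2` carries the change (1H-imidazol-1-yl in place of diethylamino on an aromatic carbon). For the measured compounds named here, no measured step bears directly on this change: the one step kept a dialkylamino group throughout, whereas here that group is removed and an aromatic ring takes its place. The estimate therefore rests on the value of compound 2 alone, without a step to borrow from. Given that the lone gain in the set came with a dialkylamino group, a step to a higher number is expected for compound 3, of size a 4.5-fold higher number from compound 2 to compound 3 (0.66 log units; beyond the scatter), with wide uncertainty. Compound 3 is estimated at 2500 nM, within a range from 800 nM to 8000 nM.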

Compound 3, half-maximal inhibitory concentration: > 6600 nM
Compound 3: no number, only a limit; the forecaster's own chance of this, stated with the estimate: 10%; middle value at least 2.6-fold (0.42 log units) away from the limit.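

The entry for compound 3 in this assay is a limit and not a number: the limit of > 6600 nM in this assay, at which 1 of the 3 values shown sits. Even so, the change can be read in both directions: the 1H-imidazol-1-yl group in place of diethylamino gives an at least 12-fold higher number from compound 2 to compound 3 (1.07 log units; beyond the scatter), and in place of dimethylamino it gives an at least 3.5-fold higher number from compound 1 to compound 3 (0.54 log units; beyond the scatter). Among the compounds shown here, this shows that the position, on an aromatic carbon para to a large group, tolerates far less than the single dialkylamino step suggested, and since diethylamino and 1H-imidazol-1-yl match in heavy atoms, that count alone does not set the read-out here.

The compounds shown leave open whether a saturated ring amine such as pyrrolidine or morpholine would behave like the dialkylamino groups or like the imidazolyl ring. They also leave open whether a longer chain, such as dipropylamino, would extend the gain seen from dimethylamino to diethylamino.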